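Benzyl in place of methyl on the ring amide nitrogen

The source may report more compounds than this note shows. Statements on the series, on what has been measured and on what is new or still open speak of the compounds shown alone.

Measured so far:
compound 1, `Cc1ccc2c(c1)C1(C(=O)N2C)C(C#N)=C(N)Oc2cc3oc(-c4ccccc4)cc(=O)c3c(O)c21`, 5870 nM
compound 2, `CN1C(=O)C2(C(C#N)=C(N)Oc3cc4oc(-c5ccccc5)cc(=O)c4c(O)c32)c2cc(Cl)ccc21`, 4340 nM

Of the compounds shown here, two have been tested in a functional assay on K562 cells (Homo sapiens) for antiproliferative activity, read by MTT assay, with a stated time of 48 h; on this read-out higher numbers stand for weaker inhibition and lower numbers for stronger inhibition. Compound 1 gives 5870 nM, and compound 2 gives 4340 nM. For the measured compounds named here, of these two numbers, compound 1 has the higher one, but the only step between them, a 1.4-fold lower number from compound 1 to compound 2 (0.13 log units; within the scatter), is too small to count as a real difference.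

Compound 3, `Cc1ccc2c(c1)C1(C(=O)N2Cc2ccccc2)C(C#N)=C(N)Oc2cc3oc(-c4ccccc4)cc(=O)c3c(O)c21`, is not yet measured. It differs from compound 1 in one place: phenyl in place of hydrogen on a saturated chain carbon bound to an amide-type nitrogen in a ring. Going by the values given here, the single measured step concerns a different place on the shared core, the exchange of methyl for chloro on an aromatic carbon, and it tells nothing about what happens at the amide nitrogen. Among the compounds with values here, no measured step therefore bears on this change, and the expectation can rest only on the general closeness of the two numbers seen so far.

On that basis compound 3 is expected to land near compound 1, with the step from compound 1 to compound 3 estimated as a 1.2-fold lower number from compound 1 to compound 3 (0.07 log units; within the scatter). The estimate for compound 3 in this assay is 5000 nM, with a range from 1500 nM to 15000 nM.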

Compound 3, half-maximal inhibitory concentration: > 50000 nM
Compound 3: no number, only a limit (the forecaster's own chance of this, stated with the estimate: 5%); middle value at least 10-fold (1.00 log units) away from the limit.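

Moving from methyl to benzyl on an amide-type nitrogen in a ring gives an at least 8.5-fold higher number from compound 1 to compound 3 (0.93 log units; beyond the scatter), so in this assay this one change weakens inhibition by more than the usual scatter. The exchange of methyl for chloro on an aromatic carbon, by contrast, gave a 1.4-fold lower number from compound 1 to compound 2 (0.13 log units; within the scatter), so this nitrogen is the only place shown where a change has a clear effect. Compound 3 gives only a limit and not a number: the limit of > 50000 nM in this assay, at which 1 of the 3 values shown sits.

With only methyl and benzyl shown on this nitrogen, it remains open whether the loss of activity belongs to the phenyl ring itself or would come with any group longer than methyl. Ethyl, a longer open chain, or a benzyl carrying a carboxylic acid at this place would help to separate these possibilities, and it is equally open whether benzyl would have the same effect on the chloro compound 2.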